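Trimming the Amine Side Chain to a Small Acrylamide

This account rests on a few compounds, and the source may have more. Where it says the series, first, only, none or still open, it means among the compounds named here.

Compound 1 `O=C(/C=C/CNCCOc1ccc(Oc2c(-c3ccc(F)cc3)sc3cc(O)ccc23)cc1)N1CCCCC1`, compound 2 `CN(C)C(=O)/C=C/CN1CC(Oc2ccc(Oc3c(-c4ccc(F)cc4)sc4cc(O)ccc34)cc2)C1` and compound 3 `O=C(CCCNCCOc1ccc(Oc2c(-c3ccc(F)cc3)sc3cc(O)ccc23)cc1)N1CCC1` share one core and differ only in the chain carried by the amine nitrogen. In a functional assay on Ishikawa cells (Homo sapiens) for antiproliferative activity, read by CCK-8 assay, with a stated time of 48 h (on this read-out higher numbers stand for weaker inhibition and lower numbers for stronger inhibition), compound 1 gives 8430 nM. Compound 2 gives 11200 nM. Compound 3 reaches only the limit of this assay, > 25000 nM, so for compound 3 no number is known, only that it sits at the weak end of the series. The two measured steps that lead there, an at least 2.9-fold higher number from compound 1 to compound 3 (0.47 log units; beyond the scatter) and an at least 2.2-fold higher number from compound 2 to compound 3 (0.34 log units; beyond the scatter), both run toward weaker inhibition, and both end at the limit of > 25000 nM in this assay, at which 1 of the 3 values shown sits.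

Compound 4 `C=CC(=O)NCCOc1ccc(Oc2c(-c3ccc(F)cc3)sc3cc(O)ccc23)cc1` differs from compound 3 as follows: vinylcarbonyl in place of 3-((azetidin-1-yl)carbonyl)propyl on an amine nitrogen. No measured pair repeats this change, so the only guide is that the other amine-side variations shown move the number by modest amounts. The step of an at least 1.6-fold lower number from compound 3 to compound 4 (0.22 log units; that floor lies within the scatter) is therefore expected to stay small, and compound 4 is estimated at 15000 nM, within 5000 nM to 40000 nM.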

Compound 4, half-maximal inhibitory concentration: > 25000 nM
Compound 4: only a limit was reported; the forecaster's own chance of this, stated with the estimate: 35%; middle value at least 1.6-fold (0.22 log units) away from the limit.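

Shortening the chain on the amine nitrogen to vinylcarbonyl does not restore activity, and the small group gives an at least 2.9-fold higher number from compound 1 to compound 4 (0.47 log units; beyond the scatter). The comparison with the azetidine-linked compound runs the same way, with an at least 2.2-fold higher number from compound 2 to compound 4 (0.34 log units; beyond the scatter). Compound 4 is therefore the second compound, after compound 3, whose result is only a limit and not a number, and the step between these two limits cannot be read: the limit of > 25000 nM in this assay, at which 2 of the 4 values shown sit.

Where compound 3 and compound 4 really lie beyond that limit remains unknown, so their chains cannot be ranked against each other. Also open, going by these compounds, is whether a vinylcarbonyl group carrying a dimethylamino group would bring the number back toward those of compound 1 and compound 2.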